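The compounds below may be only part of what the source reports. "The series", "measured", "known", "first", "only" and "open" are said of these compounds alone.

In a functional assay for binding affinity, with Homo sapiens as the target, read by fluorescence and flow cytometry (on this read-out lower numbers stand for tighter binding and higher numbers for weaker binding), compound 1 `O=C(NC[C@H](NS(=O)(=O)c1ccc(Cl)cc1)C(=O)O)c1cc2cc(CCC3CCNCC3)sc2s1` gives 0.026 nM and compound 2 `CCCCS(=O)(=O)N[C@@H](CNC(=O)c1cc2cc(CCC3CCNCC3)sc2s1)C(=O)O` gives 5.6 nM. Compound 3 `O=C(NC[C@H](NS(=O)(=O)c1ccccc1)C(=O)O)c1cc2sc(CCC3CCNCC3)cc2s1` falls between them at 0.15 nM, the middle of the three numbers. Compound 4 `O=C(NCc1ccccc1)N[C@@H](CNC(=O)c1cc2sc(CCC3CCNCC3)cc2s1)C(=O)O` has not yet been measured. It carries benzylcarbamoyl in place of phenylsulfonyl on an amine nitrogen. For the measured compounds named here, one measured step bears on this change: butyl in place of 4-chlorophenyl on a sulfonyl sulfur gave a 220-fold higher number from compound 1 to compound 2 (2.33 log units; beyond the scatter), a large step. That step keeps the sulfonyl, so no measurement tests its replacement, and the guide is loose. A moderate move toward weaker binding in this assay is expected, well short of that large step. The expected change is a 3.3-fold higher number from compound 3 to compound 4 (0.52 log units; beyond the scatter). Compound 4 is estimated at 0.5 nM, with a range from 0.06 nM to 4 nM.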

Compound 4, dissociation constant: 33 nM
The estimate for compound 4 lay 66-fold (1.82 log units) below the measured number; measured number outside the range, above it.
By their numbers in this assay, from the lowest: compound 1; then compound 3; then compound 2; then compound 4.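

In this assay, benzylcarbamoyl in place of phenylsulfonyl on this amine nitrogen gives a 220-fold higher number from compound 3 to compound 4 (2.34 log units; beyond the scatter). The earlier step changed only the group on the sulfonyl sulfur, whereas this one shows that keeping a six-membered aromatic ring is not enough to hold the low number once the sulfonyl is gone. Nothing measured here explains the rise.

The compounds shown leave open whether the loss follows from removing the sulfonyl or from the benzyl group's extra chain carbon. Benzylsulfonyl and phenylcarbamoyl on the same nitrogen would separate these two changes.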